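The source may report more compounds than this note shows. Statements on the series, on what has been measured and on what is new or still open speak of the compounds shown alone.

Compound 1 `CC1=CC[C@H](C(C)(C)N=C=S)CC1` — in an ADME assay on Vero cells (Chlorocebus sabaeus) for inhibition, read by sulforhodamine B assay, with a stated time of 48 h (a higher number here means a weaker inhibitor of growth, a lower number a stronger inhibitor of growth), compound 1 gives no number, only > 100000 nM, which is a limit of the assay.
Compound 2 `CC1=CC[C@H](C(C)(C)NC(=S)NN)CC1` — in this assay compound 2 gives 49500 nM.
Compound 3 `COc1ccc(/C=N/NC(=S)NC(C)(C)[C@H]2CC=C(C)CC2)cc1` — in this assay compound 3 gives 12200 nM.

Compound 3 holds the lowest of the two actual numbers; compound 2 stands nearest to it with a higher value, and that gap lies beyond the scatter. Compound 4 `CC1=CC[C@H](C(C)(C)NC(=S)N/N=C/c2ccccc2Cl)CC1` differs from compound 3 by 2-chlorophenyl in place of 4-methoxyphenyl on a carbon with a double bond to nitrogen. Among the compounds with values here, the one measured step, an at least 2.0-fold lower number from compound 1 to compound 2 (0.30 log units; that floor lies within the scatter), changes the group on the saturated chain carbon and leaves the aromatic end of the molecule untouched, so it says nothing about swapping one aromatic ring for another. Within the data shown here, no measured step of that kind exists here. The expectation is therefore a step of no size beyond the scatter, given as a 1.0-fold lower number from compound 3 to compound 4 (0.01 log units; within the scatter). For compound 4 in this assay the estimated value is 12000 nM, with a range from 4000 nM to 40000 nM.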

Compound 4, concentration for 50% growth inhibition: 74600 nM
For compound 4 the middle estimate is 6.2-fold (0.79 log units) below the measured one; the measured number lies above the stated range.
By their numbers in this assay, from the lowest: compound 3; then compounds 2 and 4 (each within the scatter of the next). At a limit, above all of these: compound 1.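

Changing the aromatic ring on the carbon with a double bond to nitrogen clearly affects this assay: replacing 4-methoxyphenyl with 2-chlorophenyl gives a 6.1-fold higher number from compound 3 to compound 4 (0.79 log units; beyond the scatter), and compound 4 is therefore the weaker inhibitor of growth of this pair. Within the data shown here, the earlier step changed only the group on the saturated chain carbon, so this is the first measured evidence that the aromatic end of the molecule also affects the number, with a step beyond the scatter. Nothing measured here explains why this ring change has that effect.

The names 2-chlorophenyl and 4-methoxyphenyl differ in both the group on the ring and the number giving its place, so this single pair cannot separate those two changes. On these data alone, how a plain phenyl ring or a pyridine ring would behave at this place remains open.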